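This account rests on a few compounds, and the source may have more. Where it says the series, first, only, none or still open, it means among the compounds named here.

Of the compounds shown here, three have so far been measured in an assay on AV12 cells for binding affinity to Neuropeptide Y receptor type 1 (Homo sapiens); on this read-out higher numbers stand for weaker inhibition and lower numbers for stronger inhibition. Compound 1 `Cc1cccc2c1nc(COc1ccc(Cl)cc1)n2CCCC1CCN(Cc2ccccc2)CC1` gives 109 nM in this assay. Compound 2 `Cc1cccc2c1nc(COc1ccc(Cl)cc1)n2CCCC1CCN(CCCc2ccccc2)CC1` gives 57 nM in this assay, and the step from compound 1 to compound 2 reads a 1.9-fold lower number from compound 1 to compound 2 (0.28 log units; within the scatter). Compound 3 `CCOC(=O)CN1CCC(CCCn2c(COc3ccc(Cl)cc3)nc3c(C)cccc32)CC1` gives 427 nM in this assay, the highest of the three numbers; its nearest neighbour is compound 1, reached through a 3.9-fold higher number from compound 1 to compound 3 (0.59 log units; beyond the scatter), and its furthest is compound 2, reached through a 7.5-fold higher number from compound 2 to compound 3 (0.87 log units; beyond the scatter). Compound 4 `CCOC(=O)CCCN1CCC(CCCn2c(COc3ccc(Cl)cc3)nc3c(C)cccc32)CC1` has not yet been measured. It differs from compound 3 in one place: 2-(ethoxycarbonyl)ethyl in place of ethoxycarbonyl on a saturated chain carbon bound to an amine nitrogen in a ring. Within the data shown here, the only measured step that bears on this kind of change is the lengthening of the chain at the same place from compound 1 to compound 2, which read a 1.9-fold lower number from compound 1 to compound 2 (0.28 log units; within the scatter) and stayed within the scatter. The steps that lead into compound 3 concern the exchange of an aromatic group for the ester and say nothing about lengthening the ester chain. The account therefore expects for compound 4 a step of a 1.4-fold lower number from compound 3 to compound 4 (0.15 log units; within the scatter) in this assay, small and quite possibly within the scatter. The estimate for compound 4 in this assay is 300 nM, with a range from 110 nM to 850 nM.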

Compound 4, inhibition constant: 29 nM
Estimate against measurement, compound 4: 10-fold (1.01 log units) above, outside the stated range (below it).
By their numbers in this assay, from the lowest: compounds 4, 2 and 1 (each within the scatter of the next, the first and the last beyond it); then compound 3.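

The position tolerates the ester far better than compound 3 alone suggested, and the length of the chain carrying it turns out to matter a great deal in this assay: lengthening ethoxycarbonyl to 2-(ethoxycarbonyl)ethyl gives a 15-fold lower number from compound 3 to compound 4 (1.17 log units; beyond the scatter), whereas the comparable lengthening on the aromatic side had stayed within the scatter. The longer chain also removes the penalty the ester carried against the aromatic end groups: the step from the phenethyl partner reads a 2.0-fold lower number from compound 2 to compound 4 (0.29 log units; within the scatter), and the step from the shorter phenyl-ended partner reads a 3.8-fold lower number from compound 1 to compound 4 (0.58 log units; beyond the scatter). The exchange of phenyl for ethoxycarbonyl therefore has no single effect at this position, and its outcome depends on the chain that carries it: the same change on two cores in this assay, a 3.9-fold higher number (0.59 log units; beyond the scatter) from compound 1 to compound 3 and a 2.0-fold lower number (0.29 log units; within the scatter) from compound 2 to compound 4, 7.7-fold (0.89 log units) apart, beyond the scatter of two such steps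

Going by these compounds, whether the gain comes from chain length alone or needs the ester remains open, and a plain butyl chain, a carboxylic acid or an amide at the chain end would separate these readings. On these data alone, how far the gain extends is also open, and a chain longer than 3-(ethoxycarbonyl)propyl would show whether it continues, levels off or reverses.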